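The source may report more compounds than this note shows. Statements on the series, on what has been measured and on what is new or still open speak of the compounds shown alone.

Two members of the series have numbers in a functional assay on the whole organism (strain Swiss albino) with Mus musculus as the target, in the maximal electroshock model, with a stated time of 0.5 h; on this read-out lower numbers stand for an effect already at smaller amounts and higher numbers for an effect only at larger amounts of compound. Compound 1 `C/C(=N/NC(=O)Nc1nnc(COc2ccc3ccccc3c2)o1)c1ccc(O)cc1` gives 100 mg/kg, and compound 2 `O=C(N/N=C\c1ccc([N+](=O)[O-])cc1)Nc1nnc(COc2ccc3ccccc3c2)o1` gives 300 mg/kg; compound 2 thus stands at the highest number of the two, and its nearest neighbour, compound 1, sits at a lower number by a gap that lies beyond the scatter. Among the measured compounds shown here, no two measured compounds differ in a single place, so no step between measured compounds can be read off. Compound 3 `O=C(N/N=C\c1ccc(O)cc1)Nc1nnc(COc2ccc3ccccc3c2)o1` has not yet been measured in this assay. It is reached from compound 2 by one change: hydroxy in place of nitro on an aromatic carbon. Compound 1 also bears a hydroxy group and gives 100 mg/kg, which points toward a lower number for compound 3 than for compound 2. A step of a 3.0-fold lower number from compound 2 to compound 3 (0.48 log units; beyond the scatter) is expected, toward a smaller dose and beyond the scatter. Compound 3 is therefore estimated at 100 mg/kg, with a range from 50 mg/kg to 300 mg/kg.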

Compound 3, minimum effective dose: 100 mg/kg
For compound 3 middle estimate and measured number coincide at the digits printed; low and high end bracket the measured number.
By their numbers in this assay, from the lowest: compounds 1 and 3 (each within the scatter of the next); then compound 2.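

In this assay, among the compounds shown here, the change from 4-nitrophenyl to 4-hydroxyphenyl gives the first step that can be read at a single place: a 3.0-fold lower number from compound 2 to compound 3 (0.48 log units; beyond the scatter), so the group on this aromatic carbon does affect the minimum effective dose. The second step, no change at the digits printed from compound 1 to compound 3 (within the scatter), shows that with the hydroxy group kept, this change in the group on the amide-type nitrogen leaves the number within the scatter. Nothing measured here explains the difference between the nitro and hydroxy compounds.

As far as these compounds go, with only nitro and hydroxy compared at this place, it remains open where an amine, a methoxy group or a chlorine atom on the same aromatic carbon would fall. From the compounds shown here alone, whether the nitro-to-hydroxy step would hold on the group carried by compound 1 also remains open.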